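The source may report more compounds than this note shows. Statements on the series, on what has been measured and on what is new or still open speak of the compounds shown alone.

Measured in a functional assay for inhibition, with Rattus norvegicus as the target; a higher number here means a weaker inhibitor, a lower number a stronger inhibitor:
- compound 1 `CC(C)C(C)/N=c1\c(O)c(O)\c1=N/c1ccc(C#N)cc1`: 1900 nM
- compound 2 `CCC(C)(C)/N=c1\c(O)c(O)\c1=N/c1ccc(C#N)cc1`: > 30000 nM (a limit)

Compound 2 stands at > 30000 nM, which is a limit of the assay and not a number. Among the measured compounds shown here, on the values so far, the position is the limit of > 30000 nM in this assay, at which 1 of the 2 values shown sits.

Next is compound 3 `C[C@@H](/N=c1\c(O)c(O)\c1=N/c1ccc(C#N)cc1)c1ccccc1`, with the change (1-phenylethyl in place of 1,1-dimethylpropyl on a double-bonded nitrogen). The shared core stays, and 1,1-dimethylpropyl leaves the double-bonded nitrogen.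

For the measured compounds named here, only one measured step bears on this: an at least 15-fold higher number from compound 1 to compound 2 (1.19 log units; beyond the scatter). It is large and beyond the scatter, and it is the step that brought in the group now leaving. Going by the values given here, compound 1, at 1900 nM, gives the only actual number, so it serves as the anchor. Neither measured compound carries 1-phenylethyl, so the expectation is loose and the range is wide.

A large step towards a lower number in this assay is expected, estimated as an at least 10-fold lower number from compound 2 to compound 3 (1.00 log units; beyond the scatter). Going by these compounds, the true size stays open while one end of the comparison is a limit.

For compound 3 the expected value is 3000 nM. The estimated range runs from 500 nM to 18000 nM.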

Compound 3, half-maximal inhibitory concentration: 56 nM
Estimate against measurement, compound 3: 54-fold (1.73 log units) above, and the stated range ends above it.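

In this assay the double-bonded nitrogen is not limited to branched alkyl groups: 1-phenylethyl in place of 1,2-dimethylpropyl gives a 34-fold lower number from compound 1 to compound 3 (1.53 log units; beyond the scatter), which makes compound 3 the strongest inhibitor of the three. Replacing 1,1-dimethylpropyl with 1-phenylethyl gives an at least 530-fold lower number from compound 2 to compound 3 (2.72 log units; beyond the scatter), so a single change at this position separates a compound with a measurable value from one without. Compound 2 is a limit and not a number, so the true size of that step stays open: the limit of > 30000 nM in this assay, at which 1 of the 3 values shown sits.

The compounds shown do not separate the effect of the aromatic ring in 1-phenylethyl from that of the branching on the carbon attached to the nitrogen; 1-cyclohexylethyl and benzyl on the same nitrogen would bear on these two features. Also open, going by these compounds, are the mirror-image form of 1-phenylethyl and whether a chlorine or a methoxy group on its phenyl ring would keep the value of compound 3 at 56 nM.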